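The source may report more compounds than this note shows. Statements on the series, on what has been measured and on what is new or still open speak of the compounds shown alone.

Going by the values given here, only two compounds have been measured so far. In a physicochemical assay for lipophilicity, at pH 7.4 (a lower number here means a more polar compound, a higher number a more lipophilic compound), compound 1 (`Cc1cc(C(=O)O)nn1Cc1cc(Br)ccc1OCc1ccccc1`) gives 1.2 and compound 2 (`Cc1cc(C(N)=O)nn1Cc1cc(Cl)ccc1OCc1ccccc1`) gives 3.7 as its reading. Compound 2 therefore stands as the higher of the two, and the gap between them is larger than the usual scatter of repeated measurements. These two compounds differ in more than one place, so their gap cannot be tied to any single structural change.

The next compound, compound 3 (`Cc1cc(C(=O)NC(C)C)nn1Cc1cc(Cl)ccc1OCc1ccccc1`), comes from compound 2 through one change (isopropyl in place of hydrogen on an amide-type nitrogen), with isopropyl in place of hydrogen on an amide-type nitrogen. Among the compounds with values here, no measured pair shows this change on its own, so the expectation rests on the structural change alone, starting from compound 2 at 3.7 on the same scale. The expected step is a number 0.80 log units higher from compound 2 to compound 3 (beyond the scatter) in this assay and it points upward, a moderate rise beyond the scatter. For compound 3 the estimated value is 4.5 with a range from 4 to 5 expected around it.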

Compound 3, distribution coefficient: > 3.7
Compound 3: a limit, no number (the forecaster's own chance of this, stated with the estimate: 10%); the middle value is on the limit's open side.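

Going by these compounds alone, compound 2 and compound 3 form the first measured pair that differs in one place only, so the amide-type nitrogen can now be looked at on its own, with isopropyl in place of hydrogen. In this assay the pair gives a number no lower from compound 2 to compound 3 (the limit leaves the size open), so this change brings no drop on this scale, although the distance travelled cannot be read. Compound 3 carries a limit rather than a number, and everything said about this change rests on it: the limit of > 3.7 in this assay, at which 1 of the 3 values shown sits.

From the compounds shown here alone, whether this outcome belongs to isopropyl in particular stays open, since a methyl, a longer chain such as butyl or a cyclopropyl ring on the same nitrogen could read differently. Also open, going by these compounds, are the true number for compound 3 and whether a chain ending in an amine or a carboxylic acid, placed on that nitrogen, would move the reading the other way.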